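The compounds below may be only part of what the source reports. "The series", "measured", "known", "first", "only" and "open" are said of these compounds alone.

Compounds in hand:
compound 1 `COC(=O)c1c(Cl)cc(Cl)cc1OC(=O)COc1cc(O)c2c(=O)cc(-c3ccccc3)oc2c1` — 43600 nM
compound 2 `C=C(CCc1cc(O)c2c(=O)cc(-c3ccccc3)oc2c1)Cc1c(Br)cccc1C(=O)CC` — 40700 nM
compound 3 `COC(=O)c1ccc(C)cc1OC(=O)COc1cc(O)c2c(=O)cc(-c3ccccc3)oc2c1` — 31100 nM

All three numbers come from a functional assay on cells (T-cell, Mus musculus, strain BALB/c) for inhibition, read by MTT assay, with a stated time of 72 h; a higher number here means a weaker inhibitor, a lower number a stronger inhibitor. Compound 3 gives the lowest of the three, but its gaps to compound 2 and to compound 1 both sit within the usual scatter, so no ordering among the three is supported. Compound 4 `COC(=O)c1cc(Br)ccc1OC(=O)COc1cc(O)c2c(=O)cc(-c3ccccc3)oc2c1` has not been measured. It differs from compound 3 by a group of 11 heavy atoms (8 carbon, 2 oxygen, 1 bromine; one six-membered aromatic ring of carbon only) in place of a group of 11 heavy atoms (9 carbon, 2 oxygen; one six-membered aromatic ring of carbon only), on an oxygen next to a carbonyl group. Among the measured compounds shown here, no pair of measured compounds that differ in a single place is available, so no step size can be read from the series. The step from compound 3 to compound 4 is expected to be small, in neither direction beyond the scatter. Compound 4 is expected to give about 30000 nM, with a range from 15000 nM to 60000 nM, which means an expected step of a 1.0-fold lower number from compound 3 to compound 4 (0.02 log units; within the scatter).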

Compound 4, half-maximal inhibitory concentration: 780 nM
Estimate against measurement, compound 4: 38-fold (1.59 log units) above, outside the stated range (below it).
By their numbers in this assay, from the lowest: compound 4; then compounds 3, 2 and 1 (each within the scatter of the next).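

In this assay, placing 4-bromo-2-(methoxycarbonyl)phenyl on an oxygen next to a carbonyl group gives a 40-fold lower number from compound 3 to compound 4 (1.60 log units; beyond the scatter) with no change in the count of 11 heavy atoms. Among the compounds shown here, this position therefore responds strongly to the make-up of this group, which the earlier compounds could not show with no single-place pair among them. No measurement shown bears on the reason for this step.

As far as these compounds go, whether the bromine itself or its place on the ring carries the step stays open. Also open, from the compounds shown here alone, is whether chlorine or a nitrile there would keep it.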